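This account rests on a few compounds, and the source may have more. Where it says the series, first, only, none or still open, it means among the compounds named here.

Three compounds have been measured in a functional assay on MT4 cells (Homo sapiens) for cytotoxicity; a higher number here means that more compound is tolerated, a lower number that less compound is tolerated:

Compound 1, `CC(c1cc(O)nc(SC2CCCC2)n1)c1cccc2ccccc12`: 93000 nM
Compound 2, `CC(c1cc(O)nc(SC2CCCCC2)n1)c1cccc2ccccc12`: 45000 nM
Compound 3, `CC(c1cc(O)nc(SC2CCCC2)n1)c1c(Cl)cccc1Cl`: 78300 nM

Compounds 1 and 2 share a core and differ in a single place: cyclohexyl in place of cyclopentyl on a sulfur. This change gave a 2.1-fold lower number from compound 1 to compound 2 (0.32 log units; beyond the scatter). Compound 3 carries a different core; the difference between the core of compound 1 and the core of compound 3 is not broken down here. In this assay compound 3 stands close to compound 1, and the gap between them lies within the scatter of the measurement.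

Compound 4, `CC(c1cc(O)nc(SC2CCCCC2)n1)c1c(Cl)cccc1Cl`, has not yet been measured. It differs from compound 3 by cyclohexyl in place of cyclopentyl on a sulfur, the same change that separates compound 2 from compound 1, made at the same kind of place on the sulfur attached to an aromatic carbon. Going by the values given here, the expected step is a 2.1-fold lower number from compound 3 to compound 4 (0.31 log units; beyond the scatter), and this rests on the measured step of a 2.1-fold lower number from compound 1 to compound 2 (0.32 log units; beyond the scatter), the only example of this change in the set. On that basis compound 4 is estimated at 38000 nM, with a likely range from 20000 nM to 75000 nM.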

Compound 4, half-maximal cytotoxic concentration: > 200000 nM
Compound 4 ended at the assay's limit; the forecaster's own chance of this, stated with the estimate: 5%; at least 5.2-fold (0.72 log units) between middle value and limit.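

In this assay compound 4 gives > 200000 nM, which is a limit of the assay and not a number. Cyclohexyl in place of cyclopentyl on a sulfur gave an at least 2.5-fold higher number from compound 3 to compound 4 (0.40 log units; beyond the scatter), so in this series the change did not carry from the core of compound 1 to the core of compound 3, and the earlier step could not be transferred in either direction or size: the same change on two cores in this assay, a 2.1-fold lower number (0.32 log units; beyond the scatter) from compound 1 to compound 2 and an at least 2.5-fold higher number (0.40 log units; beyond the scatter) from compound 3 to compound 4, at least 5.2-fold (0.72 log units) apart, beyond the scatter of two such steps. These two pairs show only that the outcome of this change depends on the core here; they give no general rule, and the second step remains a bound rather than a measured size: the limit of > 200000 nM in this assay, at which 1 of the 4 values shown sits.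

The compounds shown leave open whether the same split between the two cores appears with other groups on the sulfur, such as an open butyl chain or a cyclohexyl carrying an amine. They also leave open which part of the difference between the two cores goes with the opposite steps.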